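Aryl in place of benzimidazolyl on the thioether sulfur

The source may report more compounds than this note shows. Statements on the series, on what has been measured and on what is new or still open speak of the compounds shown alone.

Among the compounds with values here, compound 3 `O=C(CSc1nc2ccccc2[nH]1)Nc1ccc2nc(NC(=O)c3ccc(C(F)(F)F)cc3)sc2c1` stands at the top of the three numbers measured so far: in a functional assay on HCT-116 cells (Homo sapiens) for antiproliferative activity, read by MTT assay, with a stated time of 72 h (a higher number here means a weaker inhibitor, a lower number a stronger inhibitor), compound 3 gives 3760 nM. Compound 1 `Nc1ccc(SCC(=O)Nc2ccc3nc(NC(=O)c4ccc(C(F)(F)F)cc4)sc3c2)cc1` gives 100 nM in this assay, and compound 2 `O=C(CSc1cccc(O)c1)Nc1ccc2nc(NC(=O)c3ccc(C(F)(F)F)cc3)sc2c1` gives 510 nM. Both steps onto compound 3 run upward: a 38-fold higher number from compound 1 to compound 3 (1.58 log units; beyond the scatter) and a 7.4-fold higher number from compound 2 to compound 3 (0.87 log units; beyond the scatter), while the step between the two aryl analogues is smaller, a 5.1-fold higher number from compound 1 to compound 2 (0.71 log units; beyond the scatter).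

Compound 4 `Cc1ccc(SCC(=O)Nc2ccc3nc(NC(=O)c4ccc(C(F)(F)F)cc4)sc3c2)c(C)c1` carries the change (2,4-dimethylphenyl in place of 1H-benzimidazol-2-yl on a sulfur). This is the reverse direction of the two steps onto compound 3, so a lower number in this assay is expected, and the size of the steps from compound 1 and compound 2 suggests a drop beyond the scatter. The entering group has no donor or acceptor, unlike the groups of compound 1 and compound 2, so the landing point is taken nearer to compound 2 than to compound 1 rather than below both.

For compound 4 the expected step is a 9.4-fold lower number from compound 3 to compound 4 (0.97 log units; beyond the scatter), giving an estimated 400 nM in this assay, with a range from 120 nM to 1500 nM.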

Compound 4, half-maximal inhibitory concentration: 320 nM
Compound 4: the middle estimate sits 1.3-fold (0.10 log units) above what was measured; the measured number falls inside the stated range.
By their numbers in this assay, from the lowest: compound 1; then compounds 4 and 2 (each within the scatter of the next); then compound 3.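

In this assay, 2,4-dimethylphenyl in place of 1H-benzimidazol-2-yl on the sulfur gives a large step (a 12-fold lower number from compound 3 to compound 4 (1.07 log units; beyond the scatter)), so an aryl group with 0 hydrogen-bond donors and 0 hydrogen-bond acceptors also stands clear of the benzimidazolyl analogue. The 3-hydroxyphenyl and 2,4-dimethylphenyl analogues cannot be told apart (a 1.6-fold lower number from compound 2 to compound 4 (0.20 log units; within the scatter)), while 4-aminophenyl remains separate (a 3.2-fold higher number from compound 1 to compound 4 (0.51 log units; beyond the scatter)), leaving compound 1 the strongest inhibitor of the four in this assay. No measurement at hand accounts for any of these steps.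

As far as these compounds go, whether the separation of compound 1 rests on the amine or on where it sits remains open; 3-aminophenyl and 4-hydroxyphenyl on the same sulfur would address both. From the compounds shown here alone, the value of an unsubstituted phenyl group also remains open, as does that of a single methyl on the ring.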